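Removing a Methyl From an Aryl Ether in a Urea Series

This account rests on a few compounds, and the source may have more. Where it says the series, first, only, none or still open, it means among the compounds named here.

Compound 1 `O=C(Nc1cccc(-n2cc(-c3ccncc3)c(-c3ccc(Cl)c(O)c3)n2)c1)Nc1cccc(C(F)(F)F)c1` gives 1340 nM in a functional assay on RPMI-8226 cells (Homo sapiens) for inhibition, read by sulforhodamine B assay, with a stated time of 48 h; a lower number here means a stronger inhibitor of growth, a higher number a weaker inhibitor of growth.
Compound 2 `COc1cc(-c2nn(-c3cccc(NC(=O)Nc4cc(C(F)(F)F)cc(C(F)(F)F)c4)c3)cc2-c2ccncc2)ccc1Cl` gives 307 nM.
Compound 3 `COc1cc(-c2nn(-c3cccc(NC(=O)Nc4cccc(C(F)(F)F)c4)c3)cc2-c2ccncc2)ccc1Cl` gives 340 nM.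

Compound 2 has the lowest number of the three, but compound 3 sits within the usual scatter of it, so the two cannot be told apart; only compound 1 is clearly separated. Compound 4 `O=C(Nc1cccc(-n2cc(-c3ccncc3)c(-c3ccc(Cl)c(O)c3)n2)c1)Nc1cc(C(F)(F)F)cc(C(F)(F)F)c1` differs from compound 2 by hydrogen in place of methyl on an oxygen on an aromatic ring. Among the measured compounds shown here, one measured step bears directly on this change and runs in the opposite direction: a 3.9-fold lower number from compound 1 to compound 3 (0.60 log units; beyond the scatter). The step of a 1.1-fold higher number from compound 2 to compound 3 (0.04 log units; within the scatter) touches a different part of the molecule and says little here. Undoing that methylation on compound 2 is therefore expected to raise the number by about the same amount, a 3.9-fold higher number from compound 2 to compound 4 (0.59 log units; beyond the scatter). Compound 4 is accordingly estimated at 1200 nM, with a range of 600 nM to 2400 nM.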

Compound 4, concentration for 50% growth inhibition: 477 nM
Beside the measured number, compound 4's estimate is 2.5-fold (0.40 log units) above it; the whole stated range lies above it.
By their numbers in this assay, from the lowest: compounds 2, 3 and 4 (each within the scatter of the next); then compound 1.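

With a second trifluoromethyl on the molecule, going from methoxy to hydroxy gives no clear loss: a 1.6-fold higher number from compound 2 to compound 4 (0.19 log units; within the scatter). That second trifluoromethyl makes a clear difference among the hydroxy compounds, a 2.8-fold lower number from compound 1 to compound 4 (0.45 log units; beyond the scatter), while the methoxy pair shows none, a 1.1-fold higher number from compound 2 to compound 3 (0.04 log units; within the scatter). The hydroxy penalty seen earlier therefore does not carry over in full, although the two readings of this change cannot be firmly separated: the same change on two cores in this assay, a 3.9-fold lower number (0.60 log units; beyond the scatter) from compound 1 to compound 3 and a 1.6-fold lower number (0.19 log units; within the scatter) from compound 4 to compound 2, 2.5-fold (0.40 log units) apart, within the scatter of two such steps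

The compounds shown leave open what an ethyl or a longer chain on this oxygen would do. They also leave open the effect of an amine in place of the hydroxy.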